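The compounds below may be only part of what the source reports. "The series", "measured", "known", "first", "only" and "open" are said of these compounds alone.

Compound 1 `c1coc(CNCCCNc2ccnc3cc(CC4CCCCC4)ccc23)c1` and compound 2 `COc1cccc(CNCCCNc2ccnc3cc(-c4ccc(F)cc4)ccc23)c1O` share one core and differ in two groups. In a physicochemical assay for acid dissociation, compound 1 gives 9.47, and in this assay compound 2 gives 9.47, so compound 2 stands level with compound 1, within the scatter. Compound 3 `COc1cccc(CNCCCNc2ccnc3cc(CC4CCCCC4)ccc23)c1O` is not yet measured; next to compound 2 it shows (cyclohexylmethyl in place of 4-fluorophenyl on an aromatic carbon). Compound 1 already carries cyclohexylmethyl rather than 4-fluorophenyl, and its value of 9.47 matches compound 2, so the expected step of no change at the digits printed from compound 2 to compound 3 (within the scatter) is none beyond the scatter. Compound 3 is expected to give 9.47, within a range from 9.17 to 9.77.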

Compound 3, acid dissociation constant: 9.47
The estimate for compound 3 equals the measured number at the digits printed, and the stated range covers the measured number.
By their numbers in this assay, from the lowest: compounds 1, 2 and 3 (each within the scatter of the next).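

In this assay, cyclohexylmethyl in place of 4-fluorophenyl on an aromatic carbon gives no change at the digits printed from compound 2 to compound 3 (within the scatter) with the rest of the molecule unchanged, a direct reading of this change that the earlier pair could not give. With cyclohexylmethyl held fixed, 2-hydroxy-3-methoxyphenyl in place of furan-2-yl on a saturated chain carbon bound to an amine nitrogen gives no change at the digits printed from compound 1 to compound 3 (within the scatter) as well. Nothing available here accounts for these results. On these data alone, whether an amine, a carboxylic acid or a longer chain on that aromatic carbon would shift the number remains open. The compounds shown also do not reveal which proton the number belongs to.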